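This account rests on a few compounds, and the source may have more. Where it says the series, first, only, none or still open, it means among the compounds named here.

Measured so far in a functional assay on MCF7 cells (Homo sapiens) for inhibition, read by sulforhodamine B assay, with a stated time of 48 h, tested at 50 uM; on this read-out higher numbers stand for more inhibition of growth at the one concentration tested and lower numbers for less inhibition of growth:

Compound 1 `CCCOc1ccc([C@@H]2CC(=O)c3cc(CC=C(C)C)c(OC)cc3O2)cc1`: 60%
Compound 2 `COc1ccc([C@@H]2C/C(=N/OCc3cn(-c4ccc(Cl)cc4C)nn3)c3cc(CC=C(C)C)c(OC)cc3O2)cc1`: 37%
Compound 3 `COc1cc2c(cc1CC=C(C)C)/C(=N/NC(N)=O)C[C@@H](c1ccc(O)cc1)O2`: 93%

Compound 2 has the lowest number of the three. Compound 1 gives 60%, and compound 3 gives 93%, which is the larger gap from compound 2. Both gaps are beyond the scatter of repeated measurements, so compound 2 is the least active of this small set.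

The next molecule, compound 4 `COc1ccc([C@@H]2C/C(=N/OCc3cn(-c4cccnc4Cl)nn3)c3cc(CC=C(C)C)c(OC)cc3O2)cc1`, differs from compound 2 in one place: 2-chloropyridin-3-yl in place of 4-chloro-2-methylphenyl on an aromatic nitrogen. In words, 2-chloropyridin-3-yl stands in place of 4-chloro-2-methylphenyl on an aromatic nitrogen of a five-membered aromatic ring with 3 nitrogen. The rest of the structure stays the same.

Going by the values given here, no pair of measured compounds shows what a change of this kind does, so the data give no direct guide to its size or direction. Compound 2, at 37%, is the closest measured relative and therefore the natural starting point. The expected step in this assay is a number 4 percentage points higher from compound 2 to compound 4 (within the scatter), which would stay within the scatter. For compound 4 the estimated value is 41%, with an expected range of 22% to 60%.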

Compound 4, percent growth inhibition at one concentration: 35%
The estimate for compound 4 lay 6 percentage points above the measured number; measured number inside the range.
By their numbers in this assay, from the lowest: compounds 4 and 2 (each within the scatter of the next); then compound 1; then compound 3.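

In this assay, placing 2-chloropyridin-3-yl where 4-chloro-2-methylphenyl stood on the aromatic nitrogen gives a number 2 percentage points lower from compound 2 to compound 4 (within the scatter) and so the read-out does not separate the two compounds. Going by these compounds alone, this is the first pair in the set that differs in only one place, and it gives the first direct reading at this position: a ring of carbon only can give way to a ring with a nitrogen, which brings in a hydrogen-bond acceptor and drops the methyl, without a change that can be told from the scatter. Nothing measured here offers an explanation for this result.

One exchange cannot show whether other groups at this position would behave the same way, or whether the chlorine on both rings plays any part, so a plain phenyl with no chlorine would be an informative comparison. A ring-free group such as a butyl chain, or a phenyl carrying a carboxylic acid or an amine, would show how far the position can be altered before growth inhibition moves beyond the scatter.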